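From 4-chlorobenzyl to 3,5-dimethoxybenzyl: notes on compound 4

A few compounds are considered here, and "the series" means these few. Any claim that something is new, unique, unknown or untested is made for them only; others in the source may bear on it.

Compound 1 (`O=C(NCc1cn(Cc2ccc(Cl)cc2)nn1)c1cn(-c2ccccc2)nc1-c1ccccc1`) anchors the series. In a functional assay on MCF7 cells (Homo sapiens) for antiproliferative activity, read by sulforhodamine B assay, with a stated time of 48 h (on this read-out lower numbers stand for stronger inhibition of growth and higher numbers for weaker inhibition of growth), compound 1 reads > 100000 nM as a limit of the assay. Compound 2 (`O=C(NCc1cn(Cc2ccc(Cl)cc2)nn1)c1cn(-c2ccccc2)nc1-c1ccc(F)cc1`) gives 130 nM as a true number. Compound 3 (`O=C(NCc1cn(Cc2ccc(Cl)cc2)nn1)c1cn(-c2ccccc2)nc1-c1ccc(Cl)cc1`) gives 28800 nM and so holds the higher of the two true numbers.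

Single exchanges on an aromatic carbon move these readings widely. Fluoro for hydrogen gives an at least 760-fold lower number from compound 1 to compound 2 (2.88 log units; beyond the scatter) as a large step, chloro for hydrogen gives an at least 3.4-fold lower number from compound 1 to compound 3 (0.54 log units; beyond the scatter) as an at least modest one, and chloro for fluoro gives a 220-fold higher number from compound 2 to compound 3 (2.35 log units; beyond the scatter) as another large one.

Compound 4 (`COc1cc(Cn2cc(CNC(=O)c3cn(-c4ccccc4)nc3-c3ccc(Cl)cc3)nn2)cc(OC)c1`) differs from compound 3 as follows: 3,5-dimethoxyphenyl in place of 4-chlorophenyl on a saturated chain carbon bound to an aromatic nitrogen on a saturated chain carbon bound to an aromatic nitrogen. Going by the values given here, none of the measured steps was made at that place, so they give no direction and show only that one exchange can matter greatly. A step of uncertain sign is therefore expected in this assay with a slight lean towards a lower number. The expected change is a 1.4-fold lower number from compound 3 to compound 4 (0.16 log units; within the scatter) as a rough estimate. An outcome for compound 4 at the assay ceiling also remains possible (the limit of > 100000 nM in this assay, at which 1 of the 3 values shown sits). The estimated value for compound 4 is 20000 nM (expected range 3000 nM to 100000 nM).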

Compound 4, concentration for 50% growth inhibition: 150 nM
The estimate for compound 4 lay 130-fold (2.12 log units) above the measured number; measured number below the stated range.
By their numbers in this assay, from the lowest: compounds 2 and 4 (each within the scatter of the next); then compound 3. At a limit, above all of these: compound 1.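

Going by these compounds alone, the place on a saturated chain carbon bound to an aromatic nitrogen proves as sensitive as the aromatic carbon exchanged in the earlier compounds: in this assay, 3,5-dimethoxyphenyl in place of 4-chlorophenyl gives (a 190-fold lower number from compound 3 to compound 4 (2.28 log units; beyond the scatter)), the first step read at this place. The weak reading of compound 3 is therefore not fixed by the chloro group on the core, since compound 4 keeps that group and still reads far lower once the other end changes. The compounds shown offer no measured property that accounts for the size of this step.

As far as these compounds go, it remains open whether the step comes from the loss of the chloro group, from the arrival of the methoxy groups or from both, and a plain benzyl group or a benzyl group carrying a single methoxy, a hydroxy or an amine at this place would separate these readings. Also open, from the compounds shown here alone, is how this exchange behaves on the fluoro counterpart, compound 2, and whether the effects at the two ends of the molecule add or overlap.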